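The source may hold more compounds than are shown below. What is called first, only, known or untested is meant among the compounds shown, and "the series" means these compounds.

In a functional assay on PC-3 cells (Homo sapiens) for inhibition, read by MTT assay, with a stated time of 96 h (on this read-out higher numbers stand for weaker inhibition of growth and lower numbers for stronger inhibition of growth), compound 1 `CC(C)C(=O)SCCCCCCNC(=O)c1cc(-c2ccncc2)n[nH]1` gives 22400 nM and compound 2 `C=CCOC(=O)SCCCCCCNC(=O)c1cc(-c2ccncc2)n[nH]1` gives 24800 nM, so compound 2 stands level with compound 1. Compound 3 `CCCCCCCC/C=C\CCCCCCCC(=O)SCCCCCCNC(=O)c1cc(-c2ccncc2)n[nH]1` returns only a limit, > 50000 nM. Compound 4 `CCC(=O)SCCCCCCNC(=O)c1cc(-c2ccncc2)n[nH]1` is reached from compound 2 by placing ethyl in place of allyloxy on a carbonyl carbon. Going by the values given here, one measured step bears on this, since allyloxy in place of isopropyl at that same carbon gave a 1.1-fold higher number from compound 1 to compound 2 (0.04 log units; within the scatter). With so small a step at this carbon, no change beyond the scatter is expected here, and the expected step is a 1.1-fold lower number from compound 2 to compound 4 (0.03 log units; within the scatter). Compound 4 is estimated at 23000 nM, with an expected range of 11000 nM to 45000 nM.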

Compound 4, concentration for 50% growth inhibition: > 50000 nM
Compound 4 was reported as a limit; the forecaster's own chance of this, stated with the estimate: 5%; middle value at least 2.1-fold (0.33 log units) away from the limit.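

Where the earlier step at this carbon moved nothing, hydrogen in place of methyl on the isopropyl group gives an at least 2.2-fold higher number from compound 1 to compound 4 (0.34 log units; beyond the scatter) and is the first change here beyond the scatter, while ethyl in place of allyloxy gives an at least 2.0-fold higher number from compound 2 to compound 4 (0.30 log units; that floor lies within the scatter) with a floor that stays within it. Compound 4 reads only as a limit in this assay, the same limit as compound 3: the limit of > 50000 nM in this assay, at which 2 of the 4 values shown sit.

From the compounds shown here alone, how far compound 4 lies past that limit stays open. So does how an amine or a carboxylic acid on this carbonyl carbon would read.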